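One Added Methyl on the Side Chain of Compound 2

The source may report more compounds than this note shows. Statements on the series, on what has been measured and on what is new or still open speak of the compounds shown alone.

Going by the values given here, in a physicochemical assay for solubility, read by HPLC, at pH 7.4 (on this read-out higher numbers stand for higher solubility and lower numbers for lower solubility), compound 2 (`CCc1c(C)[nH]c2cc(OC)c(Cl)cc2c1=O`) gives 10000 nM, the only true number among the three compounds measured. Compound 1 (`CCc1c(C)[nH]c2cc(OC)c(F)cc2c1=O`) reads < 2000 nM, which is a limit of the assay. Compound 3 (`CCCCCCCCCc1c(C)[nH]c2cc(OC)c(Cl)cc2c1=O`) reads < 2000 nM, also a limit.

Compound 4 (`COc1cc2[nH]c(C)c(C(C)C)c(=O)c2cc1Cl`) differs from compound 2 by methyl in place of hydrogen on a saturated chain carbon bound to an aromatic carbon and a saturated chain carbon: ethyl becomes isopropyl. Chloro in place of fluoro gave an at least 5.0-fold higher number from compound 1 to compound 2 (0.69 log units; beyond the scatter), but that change involves a different group and bears on this one only weakly. Heptyl in place of hydrogen on the same chain gave an at least 5.0-fold lower number from compound 2 to compound 3 (0.69 log units; beyond the scatter), so the far smaller methyl is expected to lower the number only slightly, perhaps within the scatter. That means an expected 1.4-fold lower number from compound 2 to compound 4 (0.15 log units; within the scatter). For compound 4 the estimated value is 7000 nM, with an expected range of 3000 nM to 14000 nM.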

Compound 4, solubility: > 20000 nM
Compound 4 was reported as a limit; the forecaster's own chance of this, stated with the estimate: 15%; at least 2.8-fold (0.45 log units) between middle value and limit.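

In this assay, ethyl to isopropyl gives an at least 2.0-fold higher number from compound 2 to compound 4 (0.30 log units; that floor lies within the scatter), so a methyl on this saturated chain carbon does not pull the number down as heptyl did on the same side chain, where the change gave an at least 5.0-fold lower number from compound 2 to compound 3 (0.69 log units; beyond the scatter). Adding carbon to this side chain therefore does not always lower the number: compound 3 fits that idea, while compound 4 goes against it. The reading for compound 4 is a limit, so the true size of this step remains unknown: the limit of > 20000 nM in this assay, at which 1 of the 4 values shown sits.

Going by these compounds, whether a tert-butyl group, a cyclopropyl ring or an amine at this place would read like compound 2 or like compound 4 remains open.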